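Heteroaryl amide exchange: half-life working notes

The source may report more compounds than this note shows. Statements on the series, on what has been measured and on what is new or still open speak of the compounds shown alone.

compound 1 `Cc1nnsc1C(=O)NC1(C(=O)N[C@H](C)c2ccc(-n3nc(Cl)c4ccccc43)cc2F)CC1`: 2.4 h
compound 2 `C[C@@H](NC(=O)C1(NC(=O)c2cncs2)CC1)c1ccc(-n2nc(Cl)c3ccccc32)cc1F`: 4.3 h

In an in vivo ADME assay on the whole organism (strain Mongrel) for metabolic stability, with Canis familiaris (Canis lupus familiaris) as the target (a lower number here means that the compound disappears faster, a higher number that the compound lasts longer), compound 2 stands highest of the two numbers; nearest is compound 1, and the step of a 1.8-fold higher number from compound 1 to compound 2 (0.25 log units; within the scatter) lies within the scatter. Compound 3 `Cc1cncc(C(=O)NC2(C(=O)N[C@H](C)c3ccc(-n4nc(Cl)c5ccccc54)cc3F)CC2)c1` differs from compound 2 as follows: 5-methylpyridin-3-yl in place of 1,3-thiazol-5-yl on a carbonyl carbon. Among the measured compounds shown here, no measured step covers this exchange; the only step at the same carbonyl, a 1.8-fold higher number from compound 1 to compound 2 (0.25 log units; within the scatter), stayed within the scatter, so no move beyond the scatter is expected here. For compound 3 the expected value in this assay is 4 h, with a range from 2 h to 8 h. The expected step is a 1.1-fold lower number from compound 2 to compound 3 (0.03 log units; within the scatter).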

Compound 3, half-life: 2.6 h
Compound 3: middle estimate off by 1.5-fold (0.19 log units), on the high side; measured number inside the range.
By their numbers in this assay, from the lowest: compounds 1, 3 and 2 (each within the scatter of the next).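

In this assay, a six-membered aromatic ring on the carbonyl carbon stays within the scatter of both five-membered groups (a 1.7-fold lower number from compound 2 to compound 3 (0.22 log units; within the scatter); a 1.1-fold higher number from compound 1 to compound 3 (0.03 log units; within the scatter)). Up to this point only five-membered rings had been compared here, and this exchange adds a change of ring size without a step beyond the scatter. No measured evidence bears on why this is so.

Going by these compounds, it remains open whether a non-aromatic group on this carbonyl carbon, such as an aminomethyl or carboxylic acid-bearing chain, would move the half-life beyond the scatter.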